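Swapping the pyrrolidine amine on two related cores

The source may report more compounds than this note shows. Statements on the series, on what has been measured and on what is new or still open speak of the compounds shown alone.

Measured compounds:
compound 1, `CCNCC1CCN(c2c(F)cc3c(=O)c(C(=O)O)cn(C4CC4)c3c2C(F)(F)F)C1`, 120 ug/mL
compound 2, `CCNCC1CCN(c2nc3c(cc2F)c(=O)c(C(=O)O)cn3C2CC2)C1`, 160 ug/mL
compound 3, `CC1(CN)CCN(c2c(F)cc3c(=O)c(C(=O)O)cn(C4CC4)c3c2C(F)(F)F)C1`, 110 ug/mL

In a functional assay on V79 cells (Cricetulus griseus) for cytotoxicity, read by colony formation (a lower number here means a stronger inhibitor, a higher number a weaker inhibitor), compound 1 gives 120 ug/mL, compound 2 gives 160 ug/mL and compound 3 gives 110 ug/mL. The three numbers lie within the scatter of one another, so no order among them can be claimed. Compound 3 arises from compound 1 by 3-(aminomethyl)-3-methylpyrrolidin-1-yl in place of 3-((ethylamino)methyl)pyrrolidin-1-yl on an aromatic carbon, and this step made a 1.1-fold lower number from compound 1 to compound 3 (0.04 log units; within the scatter).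

Compound 4, `CC1(CN)CCN(c2nc3c(cc2F)c(=O)c(C(=O)O)cn3C2CC2)C1`, has not yet been measured. It arises from compound 2 by 3-(aminomethyl)-3-methylpyrrolidin-1-yl in place of 3-((ethylamino)methyl)pyrrolidin-1-yl on an aromatic carbon. The difference between the cores of compound 1 and compound 2 is not broken down here. Around the place of the change the surroundings differ: in compound 1 the ring is of carbon only and the place is ortho to a trifluoromethyl group, whereas in compound 2 the ring has one nitrogen and the place is next to the ring nitrogen. The change is therefore the same kind of change, not the same.

The step from compound 2 to compound 4 is expected to be a 1.1-fold lower number from compound 2 to compound 4 (0.03 log units; within the scatter), resting on the step of a 1.1-fold lower number from compound 1 to compound 3 (0.04 log units; within the scatter), which stayed within the scatter. Compound 4 is thus expected to give about 150 ug/mL in this assay, likely between 90 ug/mL and 250 ug/mL.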

Compound 4, half-maximal inhibitory concentration: 25 ug/mL
The estimate for compound 4 lay 6.0-fold (0.78 log units) above the measured number, and the stated range ends above it.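

In this assay, putting 3-(aminomethyl)-3-methylpyrrolidin-1-yl in place of 3-((ethylamino)methyl)pyrrolidin-1-yl gave a 6.4-fold lower number from compound 2 to compound 4 (0.81 log units; beyond the scatter), so on this core the swap produced a clearly stronger inhibitor. The size of the effect did not carry over from one core to the other, so a result from one core is a poor guide to the other here: the same change on two cores in this assay, a 1.1-fold lower number (0.04 log units; within the scatter) from compound 1 to compound 3 and a 6.4-fold lower number (0.81 log units; beyond the scatter) from compound 2 to compound 4, 5.9-fold (0.77 log units) apart, beyond the scatter of two such steps This does not show which difference between the cores matters, such as the ring nitrogen or the trifluoromethyl group, and it rests on just one pair of compounds per core.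

From the compounds shown here alone, the change also alters two things at once, so it remains open whether the gain comes from losing the ethyl group on the amine or from adding the methyl group on the ring, and a plain 3-(aminomethyl)pyrrolidin-1-yl group would help separate them. Going by these compounds, how the swap behaves on a third core, for example one carrying a methoxy group in place of the trifluoromethyl group, also remains open.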